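A methyl group moves: compound 3 to compound 4

A few compounds are considered here, and "the series" means these few. Any claim that something is new, unique, unknown or untested is made for them only; others in the source may bear on it.

- compound 1 `CC1(Cc2ccc(C(F)(F)F)cc2)CC(S(=O)(=O)c2ccc(F)cc2)=C(c2ccc(/C(N)=N/O)cc2)O1`: 103000 nM
- compound 2 `CC1(Cc2cccc([N+](=O)[O-])c2)CC(S(=O)(=O)c2ccc(F)cc2)=C(c2ccc(/C(N)=N/O)cc2)O1`: 86600 nM
- compound 3 `Cc1ccc(CC2(C)CC(S(=O)(=O)c3ccc(F)cc3)=C(c3ccc(/C(N)=N/O)cc3)O2)cc1`: 54400 nM

The three compounds share one core and differ only in the aryl group of the benzyl arm. In an ADME assay on cells (Peritoneal macrophage, Mus musculus, strain Balb/c) for cytotoxicity, read by resazurin assay, with a stated time of 72 h (a higher number here means that more compound is tolerated, a lower number that less compound is tolerated), compound 3 gives 54400 nM. Its number stands within the scatter of the other two, as a 1.9-fold lower number from compound 1 to compound 3 (0.28 log units; within the scatter) and a 1.6-fold lower number from compound 2 to compound 3 (0.20 log units; within the scatter) show.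

Compound 4 `Cc1ccccc1CC1(C)CC(S(=O)(=O)c2ccc(F)cc2)=C(c2ccc(/C(N)=N/O)cc2)O1` has not yet been measured. It keeps the same atoms as compound 3 but joins them differently: 2-methylphenyl in place of 4-methylphenyl on a saturated chain carbon bound to a saturated ring carbon. The change is 2-methylphenyl in place of 4-methylphenyl on a saturated chain carbon bound to a saturated ring carbon.

For the measured compounds named here, no measured step moves a methyl group in this way, so the evidence is indirect. The nearest evidence is the three steps at this same aryl group. Besides the two above, there is a 1.2-fold lower number from compound 1 to compound 2 (0.08 log units; within the scatter). Even these exchanges of different groups stay within the scatter, so a step beyond the scatter is not expected here, and no direction is favoured. The estimated step is a 1.2-fold higher number from compound 3 to compound 4 (0.08 log units; within the scatter). For compound 4 the expected value in this assay is 65000 nM, with an estimated range of 30000 nM to 120000 nM.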

Compound 4, half-maximal cytotoxic concentration: 77600 nM
Estimate against measurement, compound 4: 1.2-fold (0.08 log units) below; low and high end bracket the measured number.
By their numbers in this assay, from the lowest: compounds 3, 4, 2 and 1 (each within the scatter of the next).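

Moving the methyl group, the only exchange among these compounds that keeps the same atoms, gives in this assay a 1.4-fold higher number from compound 3 to compound 4 (0.15 log units; within the scatter) and so shows that rearranging this aryl group, with no atom gained or lost, does not carry the number beyond the scatter. The 2-methylphenyl group also stays close to the two other aryl groups, with a 1.1-fold lower number from compound 2 to compound 4 (0.05 log units; within the scatter) and a 1.3-fold lower number from compound 1 to compound 4 (0.12 log units; within the scatter) as the printed steps, so all four groups on the saturated chain carbon now sit within the scatter of one another, and no group or methyl placement among them stands apart. No measurement is available here that would explain these small differences.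

The compounds shown leave open whether the number would hold with an amine or a carboxylic acid on this aryl ring, or with a longer chain in place of the single chain carbon that carries it. As far as these compounds go, all four also keep the shared core unchanged, so how a change elsewhere in the structure would read in this assay remains unknown.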